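Swapping phenyl for methyl on a pyrazoline sulfonylurea

The source may hold more compounds than are shown below. What is called first, only, known or untested is meant among the compounds shown, and "the series" means these compounds.

Measured compounds:
compound 1 `COc1ccc(C2=NN(C(=O)NS(=O)(=O)c3ccc(Cl)cc3)CC2C)c(OC)c1`: 14.6%
compound 2 `COc1ccc(C2=NN(C(=O)NS(=O)(=O)c3ccc(C)cc3)CC2c2ccccc2)c(OC)c1`: 6.33%

In a functional assay on the whole organism (strain albino) for inhibition, with Rattus norvegicus as the target, read by paw edema, with stated times of 30 min and 2 h, at a dose of 25 mg/kg by the intraperitoneal route (on this read-out lower numbers stand for less inhibition and higher numbers for more inhibition at the one dose given (going by the name of the read-out)), compound 2 gives the lowest of the two numbers shown, but compound 1 sits only a little higher, a gap within the scatter, so the two cannot be told apart. Compound 3 `COc1ccc(C2=NN(C(=O)NS(=O)(=O)c3ccc(C)cc3)CC2C)c(OC)c1` is not yet measured. It differs from compound 2 by methyl in place of phenyl on a saturated ring carbon. Compound 1 already carries methyl at that saturated ring carbon and shows a similarly low number, so no step beyond the scatter is expected in this assay. The value of compound 3 is estimated at 12%, between 2% and 26%, a change of a number 5.7 percentage points higher from compound 2 to compound 3 (within the scatter) that is expected to stay within the scatter.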

Compound 3, a percentage reported as inhibition, in the whole organism at one dose (the size of the read-out at that dose, not a potency): 27.3%
The estimate for compound 3 lay 15.3 percentage points below the measured number; the measured number lies above the stated range.
By their numbers in this assay, from the lowest: compounds 2 and 1 (each within the scatter of the next); then compound 3.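

In this assay, methyl in place of phenyl on the saturated ring carbon gives a number 21 percentage points higher from compound 2 to compound 3 (beyond the scatter), so this position does respond to a change, something compounds 1 and 2 could not show, as they differ in two places. With methyl on that ring carbon, methyl in place of chloro on an aromatic carbon gives a number 12.7 percentage points higher from compound 1 to compound 3 (beyond the scatter), so that second place matters as well. Nothing available explains either step.

The compounds shown leave open how an ethyl chain or an amine on the saturated ring carbon would read. They also leave open whether the phenyl to methyl step holds with chloro on the aromatic carbon.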